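The compounds below may be only part of what the source reports. "The series", "measured", "known", "first", "only" and "open" are said of these compounds alone.

Of the compounds shown here, three built on one shared core have been measured in a functional assay, with a stated time of 30 min; a lower number here means a stronger inhibitor, a higher number a weaker inhibitor. Compound 1 `COc1ccc(C2CC(=NOC(=O)c3ccc(F)cc3)CC(c3ccc(OC)cc3)N2C)cc1` gives 152000 nM, compound 2 `COc1ccc(C2CC(=NOC(=O)c3cc([N+](=O)[O-])cc([N+](=O)[O-])c3)CC(c3ccc(OC)cc3)N2C)cc1` gives 312000 nM, and compound 3 `COc1ccc(C2CC(=NOC(=O)c3ccccc3O)CC(c3ccc(OC)cc3)N2C)cc1` gives 29000 nM. Among these three numbers compound 3 stands lowest: the steps run a 5.2-fold lower number from compound 1 to compound 3 (0.72 log units; beyond the scatter) and an 11-fold lower number from compound 2 to compound 3 (1.03 log units; beyond the scatter), while a 2.1-fold higher number from compound 1 to compound 2 (0.31 log units; beyond the scatter).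

Compound 4 `COc1ccc(C2CC(=NOC(=O)c3ccc(OC)cc3OC)CC(c3ccc(OC)cc3)N2C)cc1` differs from compound 3 in one place: 2,4-dimethoxyphenyl in place of 2-hydroxyphenyl on a carbonyl carbon. For the measured compounds named here, no measured step covers this exact exchange. Going by the values given here, the two steps that bear on it are those arriving at compound 3, a 5.2-fold lower number from compound 1 to compound 3 (0.72 log units; beyond the scatter) and an 11-fold lower number from compound 2 to compound 3 (1.03 log units; beyond the scatter), and both show that each aryl group tried in place of the one in compound 3 has gone with a higher number in this assay, by a modest or a large margin. Compound 4 likewise carries an aryl group other than that of compound 3, and a higher number than for compound 3 is therefore expected. The entering group is itself untested, and the expected step is placed nearer the modest end, a 2.8-fold higher number from compound 3 to compound 4 (0.44 log units; beyond the scatter). The estimate for compound 4 in this assay is 80000 nM, with a range from 25000 nM to 250000 nM.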

Compound 4, half-maximal inhibitory concentration: 80000 nM
Estimate against measurement, compound 4: no gap at the digits printed; the measured number falls inside the stated range.
By their numbers in this assay, from the lowest: compound 3; then compounds 4 and 1 (each within the scatter of the next); then compound 2.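

In this assay, 2,4-dimethoxyphenyl in place of 2-hydroxyphenyl on the carbonyl carbon gives a 2.8-fold higher number from compound 3 to compound 4 (0.44 log units; beyond the scatter), so a third aryl group set against that of compound 3 has also gone with a higher number, and the 2-hydroxyphenyl compound stays lowest of the four. The entering group still stands clear of the 3,5-dinitrophenyl group, with a 3.9-fold lower number from compound 2 to compound 4 (0.59 log units; beyond the scatter), but it cannot be told apart from the 4-fluorophenyl group, with a 1.9-fold lower number from compound 1 to compound 4 (0.28 log units; within the scatter). The four aryl groups at this position now fall into three tiers: compound 3 alone, compounds 1 and 4 together, and compound 2 alone.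

No measurement shown here accounts for any of these differences. Going by these compounds, the step from compound 3 to compound 4 removes the hydroxy group and adds two methoxy groups at once, and the two changes cannot be separated here, so it remains open whether the hydroxy group itself matters and whether an amine or a carboxylic acid in its place would hold the lower number.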